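The compounds below may be only part of what the source reports. "The series", "measured", "known", "first", "only" and "open" are said of these compounds alone.

Working notes on the series. Compound 2 `CC1=NN(c2ccccc2)C(=O)C12C=CC(=O)C=C2c1cccc(C)c1` is the reference point for the step under consideration, and it is measured in a functional assay on HCT-116 cells (Homo sapiens) for antiproliferative activity, read by CCK-8 assay, with a stated time of 72 h; on this read-out higher numbers stand for weaker inhibition and lower numbers for stronger inhibition. In this read-out compound 2 gives only a limit of the assay, > 100000 nM. Compound 1 `CC1=NN(c2ccc(Br)cc2)C(=O)C12C=CC(=O)C=C2c1cccc(C)c1` also gives only a limit, > 100000 nM, in this assay. The single-site step that the two limits leave unreadable from compound 1 to compound 2 is therefore unreadable; both values sit at the limit of > 100000 nM in this assay, at which 2 of the 3 values shown sit. Within the data shown here, compound 3 `CC1=NN(c2cccc(Cl)c2)C(=O)C12C=CC(=O)C=C2c1ccc(C)cc1` gives 2400 nM in this assay, but no single-site step connects it to compound 2 or to compound 4, so it only shows that a number within range can be obtained.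

Compound 4 `CC1=NN(c2ccccc2)C(=O)C12C=CC(=O)C=C2c1ccccc1` is not yet measured. Its difference from compound 2 is hydrogen in place of methyl on an aromatic carbon. Among the measured compounds shown here, no measured step bears directly on this change; the only measured single-site step is the unreadable one at the limit. Compound 4 is therefore expected to give about 150000 nM, with a range from 30000 nM to 600000 nM, most probably again reported only as a limit. The step that the limit leaves unreadable from compound 2 to compound 4 is expected to stay within the scatter.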

Compound 4, half-maximal inhibitory concentration: 17800 nM
The estimate for compound 4 lay 8.4-fold (0.93 log units) above the measured number; the measured number lies below the stated range.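

Among these compounds, replacing 3-methylphenyl with phenyl gives an at least 5.6-fold lower number from compound 2 to compound 4 (0.74 log units; beyond the scatter), which means stronger inhibition and is the first single-site step that can be read; the step between the limits cannot. In this assay compound 2 gives > 100000 nM, a limit of the assay and not a number, so this step has a lower bound on its size and no fixed value: the limit of > 100000 nM in this assay, at which 2 of the 4 values shown sit. The methyl on this aromatic carbon is therefore a site where one change moves the read-out clear of the limit, which the bromo to hydrogen change could not show.

Going by these compounds, whether another group at this place, such as methoxy or an amine, would stay close to compound 4 or return to the limit remains open. On these data alone, whether the same change holds in the presence of the bromo of compound 1 also remains open.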